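Adding fluorine to an inactive phenyl analogue

The source may hold more compounds than are shown below. What is called first, only, known or untested is meant among the compounds shown, and "the series" means these compounds.

Compound 1 `Nc1ncnn2c([C@@H]3O[C@H](CO)[C@@H](O)[C@H]3O)cc(C#CC3CC3)c12` gives 40 nM in a functional assay on K562 cells (Homo sapiens) for antiproliferative activity, with a stated time of 72 h; a higher number here means a weaker inhibitor, a lower number a stronger inhibitor. Compound 2 `Nc1ncnn2c([C@@H]3O[C@H](CO)[C@@H](O)[C@H]3O)cc(-c3ccccc3)c12` carries phenyl in place of 2-cyclopropylethynyl on an aromatic carbon, and in this assay compound 2 reaches only the limit > 100000 nM. The step of an at least 2500-fold higher number from compound 1 to compound 2 (3.39 log units; beyond the scatter) thus ends at a limit rather than a number (the limit of > 100000 nM in this assay, at which 1 of the 2 values shown sits). Compound 3 `Nc1ncnn2c([C@@H]3O[C@H](CO)[C@@H](O)[C@H]3O)cc(-c3ccccc3F)c12` differs from compound 2 by fluoro in place of hydrogen on an aromatic carbon. Among the measured compounds shown here, no measured step covers this change, and the one measured step finishes at a limit, so compound 3 is expected to stay near that limit, with a number no higher from compound 2 to compound 3 (the limit leaves the size open) amounting to essentially no change. Compound 3 is estimated at 100000 nM, in a range from 20000 nM to 300000 nM.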

Compound 3, half-maximal inhibitory concentration: > 100000 nM
Compound 3: a limit, no number; the forecaster's own chance of this, stated with the estimate: 80%; the middle value lies on the limit itself.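

In this assay compound 3 gives > 100000 nM, which is a limit and not a number. Compound 2 and compound 3 both sit at a limit, so the step between them cannot be read, and fluoro on the six-membered aromatic ring, ortho to a large group, shows no measurable recovery. Putting 2-fluorophenyl in place of 2-cyclopropylethynyl gives an at least 2500-fold higher number from compound 1 to compound 3 (3.39 log units; beyond the scatter), and a second aryl compound now rests at the same limit: the limit of > 100000 nM in this assay, at which 2 of the 3 values shown sit.

As far as these compounds go, whether an amine or a methoxy group on that ring would bring a number back remains open. So does whether a longer chain carrying the 2-cyclopropylethynyl triple bond would hold the activity of compound 1.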